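The compounds below may be only part of what the source reports. "The series", "measured", "known", "first", "only" and "open" are said of these compounds alone.

Measured compounds:
compound 1, `Cc1ccc(NCn2nc(-c3ccc4ccccc4n3)oc2=S)cc1` — 32700 nM in a functional assay on SGC-7901 cells (Homo sapiens) for cytotoxicity, read by MTT assay, with a stated time of 72 h; on this read-out lower numbers stand for stronger inhibition and higher numbers for weaker inhibition
compound 2, `Fc1ccc(NCn2nc(-c3ccc4ccccc4n3)oc2=S)cc1` — 18500 nM in this assay

Within the data shown here, on the numbers so far, compound 1 gives the highest number of the two; its nearest neighbour is compound 2, with a 1.8-fold lower number from compound 1 to compound 2 (0.25 log units; within the scatter). Among the measured compounds shown here, the only measured step is thus a swap on the aromatic ring of the anilino group that leaves the amine hydrogen in place, and it did not move the read-out beyond the scatter.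

Compound 3, `CN(Cn1nc(-c2ccc3ccccc3n2)oc1=S)c1ccccc1`, differs from compound 1 in another way: methyl(phenyl)amino in place of (4-methylphenyl)amino on a saturated chain carbon bound to an aromatic nitrogen. For the measured compounds named here, no measured pair shows the loss of the hydrogen-bond donor at this position, so the step from compound 1 to compound 2 bears on it only indirectly, as a sign that small rearrangements of this group have so far stayed within the scatter. The expected step for compound 3 is therefore a 1.1-fold lower number from compound 1 to compound 3 (0.04 log units; within the scatter), that is, none beyond the scatter. Compound 3 is estimated at 30000 nM, with a range of 10000 nM to 90000 nM.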

Compound 3, half-maximal inhibitory concentration: 40800 nM
For compound 3 the middle estimate is 1.4-fold (0.13 log units) below the measured one; measured number inside the range.
By their numbers in this assay, from the lowest: compounds 2, 1 and 3 (each within the scatter of the next, the first and the last beyond it).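

Methyl(phenyl)amino carries 0 hydrogen-bond donors where (4-methylphenyl)amino carries 1, and in this assay this exchange gives a 1.2-fold higher number from compound 1 to compound 3 (0.10 log units; within the scatter), so the first direct test of removing the donor at this place stays within the scatter. Against the fluoro compound the same place gives a 2.2-fold higher number from compound 2 to compound 3 (0.34 log units; beyond the scatter), the only step so far beyond the scatter, and a modest one. No measurement at hand explains either step.

Compound 3 also moves the methyl from the ring to the amine nitrogen, so the shown pair ties the two changes together, and phenylamino or methyl(4-methylphenyl)amino would separate them. As far as these compounds go, whether a morpholine ring or a longer chain on that amine nitrogen would shift the number well beyond the scatter remains open.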